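The compounds below may be only part of what the source reports. "The series", "measured", "known", "first", "only" and "open" are said of these compounds alone.

In a functional assay on RAW264.7 cells (Mus musculus) for cytotoxicity (on this read-out higher numbers stand for lower toxicity in this test and lower numbers for higher toxicity in this test), compound 1, with the structure `CC(C)COc1nn(-c2ccc(Oc3ccccc3)cc2)c(=O)o1`, gives > 100000 nM, which is a limit of the assay and not a number. Compound 2, with the structure `CCCCCCOc1nn(-c2ccccc2)c(=O)o1`, gives > 100000 nM in this assay, again a limit rather than a number. Compound 2 thus stands at the limit shared by both values shown, as set out in the limit of > 100000 nM in this assay, at which 2 of the 2 values shown sit. Compound 3, with the structure `CC(C)COc1nn(-c2ccccc2)c(=O)o1`, has not yet been measured in this assay. It differs from compound 2 by isopropyl in place of pentyl on a saturated chain carbon bound to an oxygen on an aromatic ring. Among the measured compounds shown here, no step between two measured compounds of this kind is known here, so the size of the step from compound 2 to compound 3 can only be expected. Compound 3 is expected to show no step beyond the scatter, the step from compound 2 to compound 3 being estimated at a number no higher from compound 2 to compound 3 (the limit leaves the size open). Compound 3 is therefore expected to give about 100000 nM, with a range from 50000 nM to 200000 nM, most likely again reported only as a limit.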

Compound 3, half-maximal cytotoxic concentration: > 100000 nM
Compound 3 gave a limit, no number (the forecaster's own chance of this, stated with the estimate: 85%); the middle value sits exactly at the limit.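

No step can be read among compound 1, compound 2 and compound 3, which all stand at one limit of this assay, not at a number: the limit of > 100000 nM in this assay, at which 3 of the 3 values shown sit.

The compounds shown leave open what concentration would prove toxic in this assay, and whether isopropyl in place of pentyl or hydrogen in place of phenoxy would change it.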